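The compounds below may be only part of what the source reports. "The series", "measured", "known", "first", "only" and "open" are said of these compounds alone.

Four compounds belong to this set, and three of them have been tested in an ADME assay on WI-38 cells (Homo sapiens) for antiproliferative activity, read by MTT assay, with a stated time of 72 h; on this read-out lower numbers stand for stronger inhibition and higher numbers for weaker inhibition. Compound 1, `CCCCCc1ccc(C#Cc2c(-c3ccc(CCCCC)cc3)oc3nc(=O)n(Cc4cn(-c5ccc(Cl)cc5)nn4)cc23)cc1`, is the starting point. In this assay compound 1 reaches only the detection limit, > 100000 nM, which is a limit and not a measured number. Compound 2, `CCCCCCC#Cc1c(CCCCCC)oc2nc(=O)n(Cc3cn(-c4ccc(Cl)cc4)nn3)cc12`, has a different core; the difference between the two cores is not broken down here. In this assay compound 2 likewise stops at a limit, > 100000 nM. Compound 3, `CCCCCCC#Cc1c(CCCCCC)oc2nc(=O)n(Cc3cn(Cc4ccccc4)nn3)cc12`, differs from compound 2 in one place: benzyl in place of 4-chlorophenyl on an aromatic nitrogen. In this assay compound 3 gives 23400 nM. The change thus produces an at least 4.2-fold lower number from compound 2 to compound 3 (0.63 log units; beyond the scatter); its true size is open because of the limit of > 100000 nM in this assay, at which 2 of the 3 values shown sit, so the step can only be read as a minimum.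

Compound 4, `CCCCCc1ccc(C#Cc2c(-c3ccc(CCCCC)cc3)oc3nc(=O)n(Cc4cn(Cc5ccccc5)nn4)cc23)cc1`, has not yet been measured. It stands to compound 1 exactly as compound 3 stands to compound 2: benzyl in place of 4-chlorophenyl on an aromatic nitrogen. The surroundings of the change read the same in both pairs, so this is the same kind of change made on a different core. The step is expected to be an at least 2.5-fold lower number from compound 1 to compound 4 (0.39 log units; beyond the scatter), resting on the step that the same change gave in an at least 4.2-fold lower number from compound 2 to compound 3 (0.63 log units; beyond the scatter) and on compound 1 sitting at the limit of > 100000 nM in this assay, at which 2 of the 3 values shown sit. Compound 4 is therefore estimated at 40000 nM, with a likely range from 15000 nM to 150000 nM.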

Compound 4, half-maximal inhibitory concentration: 2650 nM
For compound 4 the middle estimate is 15-fold (1.18 log units) above the measured one, outside the stated range (below it).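

In this assay, benzyl in place of 4-chlorophenyl on an aromatic nitrogen gives an at least 37-fold lower number from compound 1 to compound 4 (1.57 log units; beyond the scatter), so the number falls on the core of compound 1 as it did on the core of compound 2, and the direction of the change carries over between these two cores. This does not show that the change has the same size on both cores, and the two pairs cannot settle that: the same change on two cores in this assay, an at least 4.2-fold lower number (0.63 log units; beyond the scatter) from compound 2 to compound 3 and an at least 37-fold lower number (1.57 log units; beyond the scatter) from compound 1 to compound 4; the limit leaves it open whether they differ Compound 1 and compound 2 are held at a limit and not at a measured number, so each step is only a minimum and its true size stays unknown: the limit of > 100000 nM in this assay, at which 2 of the 4 values shown sit.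

This change removes the chlorine and adds a carbon to the group on the ring nitrogen in a single move, so the compounds shown leave open which of the two goes with the lower numbers; plain phenyl and 4-chlorobenzyl at the same place would pull the two apart. Among these compounds, they also leave open how far the trend runs along a longer chain, such as 2-phenylethyl, and whether it holds on any core beyond these two, since only two pairs support it.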